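The source may report more compounds than this note shows. Statements on the series, on what has been measured and on what is new or still open speak of the compounds shown alone.

Compound 3 `CCCCSc1nsnc1C1CN2CCC[C@H]1C2` is the only one of the three measured compounds that yields a number in a functional assay on the whole organism for inhibition, with Rattus norvegicus as the target; on this read-out lower numbers stand for an effect already at smaller amounts and higher numbers for an effect only at larger amounts of compound: compound 3 gives 0.007 mg/kg. Compound 1 `CCCCSc1nsnc1C1CN2CCC[C@@H]1C2` gives only a limit of that assay, > 3 mg/kg. Compound 2 `CCCCSc1nsnc1[C@H]1CN2CCC[C@H]1C2` likewise gives only a limit, > 3 mg/kg. The two measured steps that arrive at compound 3 are an at least 420-fold lower number from compound 1 to compound 3 (2.63 log units; beyond the scatter) and an at least 420-fold lower number from compound 2 to compound 3 (2.63 log units; beyond the scatter); each of them changes only the drawn configuration at a saturated ring carbon, with the atoms and bonds unchanged.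

Compound 4 `CCSc1nsnc1C1CN2CCC[C@H]1C2` differs from compound 3 in another way: hydrogen in place of ethyl on a saturated chain carbon, two bonds along the chain from a sulfur, so that butylsulfanyl becomes ethylsulfanyl. Within the data shown here, none of the measured steps touches this chain on the sulfur; all of them concern stereochemistry alone, so no measured step bears on this change. With nothing to point either way, the expected step in this assay is a 1.4-fold higher number from compound 3 to compound 4 (0.15 log units; within the scatter), not beyond the usual scatter. Compound 4 is therefore estimated at 0.01 mg/kg, with a range from 0.003 mg/kg to 0.05 mg/kg.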

Compound 4, dose for half-maximal effect: 0.045 mg/kg
The estimate for compound 4 lay 4.5-fold (0.65 log units) below the measured number, and the stated range covers the measured number.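

In this assay the length of the chain on the sulfur turns out to count: replacing butylsulfanyl with ethylsulfanyl gives a 6.4-fold higher number from compound 3 to compound 4 (0.81 log units; beyond the scatter) and so shifts the result by more than ordinary variation. A higher number means that more compound is needed for the same effect, so this shortening costs potency, yet the cost is far smaller than an at least 420-fold lower number from compound 2 to compound 3 (2.63 log units; beyond the scatter) seen earlier for a change in drawn configuration alone. Nothing shown here explains why the shorter chain needs a larger dose.

As far as these compounds go, with only these two chain lengths, it remains open how the number changes with a propyl or hexyl chain on the sulfur, or with a chain ending in an amine or a carboxylic acid. Also open, from the compounds shown here alone, is whether the drawn configuration matters as much with the ethylsulfanyl chain as with the butylsulfanyl chain.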